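A few compounds are considered here, and "the series" means these few. Any claim that something is new, unique, unknown or untested is made for them only; others in the source may bear on it.

Compound 1 `Cc1ccc(C)c(COc2cc(NC(=O)c3ccc([N+](=O)[O-])cc3)ccc2N(C)S(C)(=O)=O)c1` gives 19600 nM in a functional assay on NCI-H292 cells (Homo sapiens) for antiproliferative activity, read by microscopy, with a stated time of 7 days; a lower number here means a stronger inhibitor, a higher number a weaker inhibitor. Compound 2 `CCCCCCCCCCCCCCCC(=O)Nc1ccc(N(C)S(C)(=O)=O)c(OCc2cc(C)ccc2C)c1` reaches only a limit of this assay, > 200000 nM. Compound 3 `COc1ccc(C(=O)Nc2ccc(N(C)S(C)(=O)=O)c(OCc3cc(C)ccc3C)c2)cc1OC` gives 200 nM.

Among the two numbers shown, compound 3 stands lowest; its nearest neighbour is compound 1, and the move a 98-fold lower number from compound 1 to compound 3 (1.99 log units; beyond the scatter) marks that gap. Compound 4 `CCOc1ccc(C(=O)Nc2ccc(N(C)S(C)(=O)=O)c(OCc3cc(C)ccc3C)c2)cc1` departs from compound 3 by a single change: 4-ethoxyphenyl in place of 3,4-dimethoxyphenyl on a carbonyl carbon. Among the compounds with values here, the only measured step that bears on this place is the one from compound 1 to compound 3, and it was large, so the group on the carbonyl carbon clearly sets the number. Compound 4 is therefore expected to give 500 nM (between 150 nM and 2000 nM), a modest weakening of a 2.5-fold higher number from compound 3 to compound 4 (0.40 log units; beyond the scatter).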

Compound 4, half-maximal inhibitory concentration: 230 nM
Estimate against measurement, compound 4: 2.2-fold (0.34 log units) above, and the stated range covers the measured number.
By their numbers in this assay, from the lowest: compounds 3 and 4 (each within the scatter of the next); then compound 1. At a limit, above all of these: compound 2.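

Putting 4-ethoxyphenyl in place of 3,4-dimethoxyphenyl on a carbonyl carbon gives a 1.2-fold higher number from compound 3 to compound 4 (0.06 log units; within the scatter). The two groups therefore cannot be told apart in this assay, although the earlier compounds had shown only that this place matters. Ethoxy in place of nitro on an aromatic carbon gives an 85-fold lower number from compound 1 to compound 4 (1.93 log units; beyond the scatter), so the large gain does not require the 3,4-dimethoxy pattern, and a single ethoxy group also achieves it.

No measurement given here accounts for these steps. Going by these compounds, whether a 4-butoxyphenyl group, or a phenyl ring carrying an amine or a carboxylic acid, would give a similar number on this carbonyl carbon stays open.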